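Triazolothiadiazine series: nitro for trifluoromethyl on the aryl arm

The source may hold more compounds than are shown below. What is called first, only, known or untested is meant among the compounds shown, and "the series" means these compounds.

Measured so far, all in a functional assay on HCT-116 cells (Homo sapiens) for inhibition, read by sulforhodamine B assay, with a stated time of 72 h; on this read-out lower numbers stand for stronger inhibition and higher numbers for weaker inhibition:
compound 1 `COc1ccc2cc(C(C)c3nnc4n3N=C(c3ccc(Br)cc3)CS4)ccc2c1`: 11700 nM
compound 2 `CC(c1ccc(-c2ccccc2)c(F)c1)c1nnc2n1N=C(c1ccc(C(F)(F)F)cc1)CS2`: 6100 nM
compound 3 `CC(C)Cc1ccc(C(C)c2nnc3n2N=C(c2ccc(Br)cc2)CS3)cc1`: 7100 nM

Compound 2 has the lowest of the three numbers in this assay. Its nearest neighbour is compound 3, a gap that sits within the scatter; the widest gap, to compound 1, also sits within the scatter. Going by the values given here, the three compounds therefore cannot be ordered on these numbers, and no single-point step between any two of them is available, as each pair differs in more than one place.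

Compound 4 `CC(c1ccc(-c2ccccc2)c(F)c1)c1nnc2n1N=C(c1ccc([N+](=O)[O-])cc1)CS2` follows from compound 2 by nitro in place of trifluoromethyl on an aromatic carbon. In words: nitro in place of trifluoromethyl on an aromatic carbon, the aromatic carbon of a six-membered aromatic ring of carbon only, para to a large group; cut one bond further out, 4-(trifluoromethyl)phenyl becomes 4-nitrophenyl.

Among the compounds with values here, there is no measured step to calibrate the change, and the measured compounds give no reading on the group at this position. The expectation is therefore that the step from compound 2 to compound 4 in this assay stays within the scatter, with no direction favoured: a 1.1-fold higher number from compound 2 to compound 4 (0.06 log units; within the scatter). Compound 4 is estimated at 7000 nM in this assay, with a range from 2500 nM to 20000 nM.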

Compound 4, half-maximal inhibitory concentration: 7100 nM
Beside the measured number, compound 4's estimate is 1.0-fold (0.01 log units) below it; the measured number falls inside the stated range.
By their numbers in this assay, from the lowest: compounds 2, 3, 4 and 1 (each within the scatter of the next).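

In this assay, going by these compounds alone, nitro in place of trifluoromethyl gives the first step that differs in one place only, a 1.2-fold higher number from compound 2 to compound 4 (0.07 log units; within the scatter). On an aromatic carbon para to a large group, the two groups therefore cannot be told apart on this read-out, even though nitro carries hydrogen-bond acceptors and trifluoromethyl carries none, so this single exchange shows that the position accepts both groups without a separation beyond the scatter. No independent measurement is available that bears on this result or could explain it.

This remains a single step on a single background, so it does not show whether the position is insensitive in general or whether these two groups merely happen to read alike. Within the data shown here, it also leaves open whether an amine, a carboxylic acid or a methoxy group in the same place would separate from compound 2, and whether the same exchange would read alike with a different arm on the other side of the shared core, such as the one in compound 3.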